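The source may hold more compounds than are shown below. What is called first, only, known or untested is meant among the compounds shown, and "the series" means these compounds.

Measured compounds:
Compound 1, `O=C(CSC(=S)N[C@H]1CCOC1=O)Nc1ccc(Br)cc1`, gives 28300 nM in a functional assay on SMMC-7721 cells (Homo sapiens) for cytotoxicity, read by MTT assay, with a stated time of 72 h; on this read-out higher numbers stand for weaker inhibition and lower numbers for stronger inhibition.
Compound 2, `O=C(CSC(=S)N[C@H]1CCOC1=O)Nc1ccc(F)cc1`, gives > 128000 nM; this value is a limit of the assay, not a number.
Compound 3, `O=C(CSC(=S)N[C@H]1CCOC1=O)Nc1ccc(C(=O)/C=C/c2ccc(Br)cc2)cc1`, gives 18000 nM.

Compounds 1 and 2 share a core and differ in one place, (fluoro in place of bromo on an aromatic carbon). This change produced an at least 4.5-fold higher number from compound 1 to compound 2 (0.65 log units; beyond the scatter), a step that rests on (the limit of > 128000 nM in this assay, at which 1 of the 3 values shown sits). Compound 3 carries a larger aryl portion than compound 1; the difference between the two cores is not broken down here. Compound 3 and compound 1 show values that lie within the usual scatter of each other, so no order between them is claimed.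

Compound 4, `O=C(CSC(=S)N[C@H]1CCOC1=O)Nc1ccc(C(=O)/C=C/c2ccc(F)cc2)cc1`, has not yet been measured. It differs from compound 3 by fluoro in place of bromo on an aromatic carbon, the same change that separates compound 1 from compound 2, made at a place described in the same words. On the strength of the step from compound 1 to compound 2, an at least 4.5-fold higher number from compound 1 to compound 2 (0.65 log units; beyond the scatter), compound 4 is expected to give a higher number than compound 3, with the step estimated as a 3.3-fold higher number from compound 3 to compound 4 (0.52 log units; beyond the scatter). The value for compound 4 is estimated at 60000 nM, between 22000 nM and 160000 nM.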

Compound 4, half-maximal inhibitory concentration: > 128000 nM
Compound 4 ended at the assay's limit; the forecaster's own chance of this, stated with the estimate: 30%; middle value at least 2.1-fold (0.32 log units) away from the limit.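

In this assay, fluoro in place of bromo on the core of compound 3 gave an at least 7.1-fold higher number from compound 3 to compound 4 (0.85 log units; beyond the scatter), and on both cores shown the change moved the number in the same direction, with each step beyond the scatter: the same change on two cores in this assay, an at least 4.5-fold higher number (0.65 log units; beyond the scatter) from compound 1 to compound 2 and an at least 7.1-fold higher number (0.85 log units; beyond the scatter) from compound 3 to compound 4; the limit leaves it open whether they differ. The value of compound 4, > 128000 nM, is a limit of the assay and not a number. The direction therefore carried over between these two pairs, but the size of the step did not become known on either core, and two pairs show no rule for other cores in the series: the limit of > 128000 nM in this assay, at which 2 of the 4 values shown sit.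

The compounds shown hold only bromo or fluoro on this aromatic carbon, which leaves open how chloro, methyl, an amine or a carboxylic acid in the same place would read on either core. They also leave open whether the bromo compounds' lower numbers would hold if the lactone-bearing part of the molecule were changed.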